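Swapping a dimethylamino chain for an acetyl group

This account rests on a few compounds, and the source may have more. Where it says the series, first, only, none or still open, it means among the compounds named here.

Compound 1 `CCCn1c(=O)n(CCCO)c(=O)c2[nH]cnc21`: in an assay on Cerebral cortex for binding affinity to adenosine receptor A1 (Cavia porcellus), read by radioligand binding (on this read-out higher numbers stand for weaker inhibition and lower numbers for stronger inhibition), compound 1 gives 12000 nM.
Compound 2 `C=CCCn1cnc2c1c(=O)n(C)c(=O)n2CCC`: in this assay compound 2 gives 6000 nM.
Compound 3 `CCCn1c(=O)n(C)c(=O)c2c1ncn2CCCN(C)C`: in this assay compound 3 gives only a limit, > 200000 nM.

Compound 3 therefore stands at the edge of what this assay can report, namely (the limit of > 200000 nM in this assay, at which 1 of the 3 values shown sits), and no number is known for it. Going by the values given here, the single measured step that leads to compound 3 is an at least 33-fold higher number from compound 2 to compound 3 (1.52 log units; beyond the scatter), a large move toward weaker inhibition. Compound 4 `CCCn1c(=O)n(C)c(=O)c2c1ncn2CC(C)=O` differs from compound 3 in one place: acetyl in place of 2-(dimethylamino)ethyl on a saturated chain carbon bound to an aromatic nitrogen. Among the compounds with values here, the dimethylamino group that entered in that large step is thus removed again, while the acetyl group that replaces it has no counterpart among the measured compounds. Within the data shown here, the only relevant evidence points to the dimethylamino group having pushed the number up, so for compound 4 a move back toward a measurable value is expected, of the size an at least 6.6-fold lower number from compound 3 to compound 4 (0.82 log units; beyond the scatter). Compound 4 is accordingly estimated at 30000 nM in this assay, within a range from 5000 nM to 200000 nM.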

Compound 4, inhibition constant: 95700 nM
The estimate for compound 4 lay 3.2-fold (0.50 log units) below the measured number; measured number inside the range.
By their numbers in this assay, from the lowest: compounds 2 and 1 (each within the scatter of the next); then compound 4. At a limit, above all of these: compound 3.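

In this assay compound 3 stands at a limit of the assay and not at a number: the limit of > 200000 nM in this assay, at which 1 of the 4 values shown sits. Going by these compounds alone, measured against that limit, the change shows an at least 2.0-fold lower number from compound 3 to compound 4 (0.32 log units; beyond the scatter), so at this position a measurable value returns once the 2-(dimethylamino)ethyl group leaves, something the earlier compounds did not show. Losing that group is not enough to reach the level of the allyl compound, however, as the comparison with acetyl in its place gives a 16-fold higher number from compound 2 to compound 4 (1.20 log units; beyond the scatter), which is a large move toward weaker inhibition.

On these data alone, the true distance between compound 3 and compound 4 stays unknown, since one end of it is only a limit. Also open, as far as these compounds go, is whether a primary amine, a carboxylic acid or a longer hydrocarbon chain at this place would fall nearer to allyl or to acetyl.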